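Moving the Phenyl One Bond Out from the Amine

The source may hold more compounds than are shown below. What is called first, only, known or untested is meant among the compounds shown, and "the series" means these compounds.

Compound 1 `O=C1C(Nc2ccccc2)=CC(=O)c2c1nc1n2[C@H]2OC[C@@H](O)[C@H]2OC1` carries a phenyl on an amine nitrogen of the shared core. In a functional assay on MGC-803 cells (Homo sapiens) for inhibition, read by sulforhodamine B assay (a higher number here means a weaker inhibitor, a lower number a stronger inhibitor), compound 1 gives 1830 nM. Compound 3 `Cc1ccc(NC2=CC(=O)c3nc4n(c3C2=O)[C@H]2OC[C@@H](O)[C@H]2OC4)cc1` gives 1420 nM, a gap from compound 1 that lies within the scatter. Compound 2 `O=C1C=C(NC2CCCCC2)C(=O)c2c1nc1n2[C@H]2OC[C@@H](O)[C@H]2OC1` gives only a limit of the assay, > 8000 nM. For the measured compounds named here, the one measured step, an at least 5.6-fold lower number from compound 2 to compound 3 (0.75 log units; beyond the scatter), starts at the limit of > 8000 nM in this assay, at which 1 of the 3 values shown sits, so its true size is unknown beyond that. Compound 4 `O=C1C(NCc2ccccc2)=CC(=O)c2c1nc1n2[C@H]2OC[C@@H](O)[C@H]2OC1` differs from compound 1 by benzyl in place of phenyl on an amine nitrogen. Going by the values given here, no measured step places a carbon between the nitrogen and the ring. Because an at least 5.6-fold lower number from compound 2 to compound 3 (0.75 log units; beyond the scatter) went with an aromatic ring sitting directly on the nitrogen, compound 4 is expected to give a higher number, estimated at 4000 nM, between 1500 nM and 12000 nM, a step of a 2.2-fold higher number from compound 1 to compound 4 (0.34 log units; beyond the scatter).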

Compound 4, half-maximal inhibitory concentration: 3490 nM
Compound 4: the middle estimate sits 1.1-fold (0.06 log units) above what was measured; low and high end bracket the measured number.
By their numbers in this assay, from the lowest: compounds 3, 1 and 4 (each within the scatter of the next, the first and the last beyond it). At a limit, above all of these: compound 2.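

Cut one bond further out, the change is anilino to benzylamino, and it gives a 1.9-fold higher number from compound 1 to compound 4 (0.28 log units; within the scatter). So in this assay this amine nitrogen carries benzyl as well as phenyl, with no difference these numbers can separate. Compound 2, with cyclohexyl, still has only a limit and no number: the limit of > 8000 nM in this assay, at which 1 of the 4 values shown sits.

Open, from the compounds shown here alone, is whether a longer chain, such as phenethyl, would move the number beyond the scatter. Also open, going by these compounds, is what an amine or a carboxylic acid on the phenyl ring would do.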